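Swapping a Triazole Arm for a Bromostyryl Chain

The source may hold more compounds than are shown below. What is called first, only, known or untested is meant among the compounds shown, and "the series" means these compounds.

Of the compounds shown here, three share a common core and have been tested in a functional assay on MCF7 cells (Homo sapiens) for cytotoxicity, read by MTT assay, with a stated time of 72 h; on this read-out higher numbers stand for weaker inhibition and lower numbers for stronger inhibition. Compound 1 `NS(=O)(=O)c1cc(-c2nnc(CN3CCN(c4ccc(Cl)cc4)CC3)o2)c(Cl)cc1SCc1ccccc1` gives 280000 nM. Within the data shown here, compound 2 `Cc1ccc(C)c(N2CCN(Cc3nnc(-c4cc(S(N)(=O)=O)c(SCc5ccccc5)cc4Cl)o3)CC2)c1` gives 51000 nM, and the step of a 5.5-fold lower number from compound 1 to compound 2 (0.74 log units; beyond the scatter) is the only change between two measured compounds that differ in a single place. Compound 3 `NC(=O)c1cn(Cc2nnc(-c3cc(S(N)(=O)=O)c(SCc4ccccc4)cc3Cl)o2)nn1` gives 78000 nM; its number is the second highest of the three, sitting within the scatter of compound 2 and beyond the scatter of compound 1.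

Compound 4 `NS(=O)(=O)c1cc(-c2nnc(/C=C/c3ccc(Br)cc3)o2)c(Cl)cc1SCc1ccccc1` has not yet been measured. It differs from compound 3 by 2-(4-bromophenyl)ethenyl in place of (4-carbamoyl-1H-1,2,3-triazol-1-yl)methyl on an aromatic carbon. Among the measured compounds shown here, no measured step alters this part of the core, so nothing here shows directly how this exchange moves the number. For the measured compounds named here, the one measured step, a 5.5-fold lower number from compound 1 to compound 2 (0.74 log units; beyond the scatter), shows only that changing a group on the far end of the chain shifts the read-out modestly.

Without a direct precedent, a change of modest size in this assay is expected, with the direction uncertain and a lower number judged slightly more likely. Compound 4 is therefore estimated at 40000 nM, with a range from 8000 nM to 200000 nM, which means an expected step of a 2.0-fold lower number from compound 3 to compound 4 (0.29 log units; within the scatter).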

Compound 4, half-maximal inhibitory concentration: 13000 nM
The estimate for compound 4 lay 3.1-fold (0.49 log units) above the measured number; measured number inside the range.
By their numbers in this assay, from the lowest: compound 4; then compounds 2 and 3 (each within the scatter of the next); then compound 1.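

In this assay, among these compounds, putting 2-(4-bromophenyl)ethenyl in place of (4-carbamoyl-1H-1,2,3-triazol-1-yl)methyl gives a 6.0-fold lower number from compound 3 to compound 4 (0.78 log units; beyond the scatter) and this is the first measured sign that the group on this aromatic carbon of the five-membered ring can itself move the read-out, since the earlier step changed only a group at the far end of the arm. The exchange keeps the size of the arm at 9 heavy atoms but replaces a five-membered aromatic ring with 3 hetero atoms by a six-membered aromatic ring of carbon only, and it goes from 1 hydrogen-bond donor and 4 acceptors to none of either, while bromine enters. No measurement of any property accompanies this step, so the data do not tell which of these differences accounts for it.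

The compounds shown leave open which part of the new arm carries the step, and a plain 2-phenylethenyl group without the bromine or a saturated 2-(4-bromophenyl)ethyl chain would help to separate those parts. Also open, on these data alone, is how the triazole arm would behave with a carboxylic acid in place of its carbamoyl group.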